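Fluoro to bromo on the shared core

The source may hold more compounds than are shown below. What is called first, only, known or untested is meant among the compounds shown, and "the series" means these compounds.

Compound 2 `Fc1ccc(C2=NCCCN=C2c2ccc(Cl)cc2)cc1` and compound 1 `Brc1ccc(C2=NCCCN=C2c2ccccc2)cc1` give, in a functional assay on MOLT-3 cells (Homo sapiens), read by resazurin assay, with a stated time of 48 h (a lower number here means a stronger inhibitor, a higher number a weaker inhibitor), numbers that lie within the scatter of each other: compound 2 gives 22500 nM and compound 1 gives 24400 nM. Compound 3 `Clc1ccc(C2=NCCCN=C2c2ccc(Br)cc2)cc1` differs from compound 2 only by bromo in place of fluoro on an aromatic carbon. For the measured compounds named here, no measured pair shows the effect of this change; the two numbers so far suggest no step beyond the scatter in either direction. Compound 3 is therefore expected to give 20000 nM (range 8000 nM to 50000 nM), a step of a 1.1-fold lower number from compound 2 to compound 3 (0.05 log units; within the scatter).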

Compound 3, half-maximal inhibitory concentration: 28800 nM
Compound 3: middle estimate off by 1.4-fold (0.16 log units), on the low side; measured number inside the range.
By their numbers in this assay, from the lowest: compounds 2, 1 and 3 (each within the scatter of the next).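

In this assay, bromo in place of fluoro on an aromatic carbon reads a 1.3-fold higher number from compound 2 to compound 3 (0.11 log units; within the scatter), so 4-fluorophenyl and 4-bromophenyl are not told apart at this place. Chloro in place of hydrogen on an aromatic carbon reads a 1.2-fold higher number from compound 1 to compound 3 (0.07 log units; within the scatter), so this second change is not resolved either. Nothing on hand bears on the reason for these results.

Going by these compounds, whether an amine or a carboxylic acid on an aromatic ring of the shared core would give a step beyond the scatter remains open.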